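From a Sulfanyl Chain to Methoxy on the Ring

The compounds below may be only part of what the source reports. "The series", "measured", "known", "first", "only" and "open" are said of these compounds alone.

In a functional assay on MV4-11 cells (Homo sapiens) for inhibition, read by resazurin assay, with a stated time of 72 h (a lower number here means a stronger inhibitor of growth, a higher number a weaker inhibitor of growth), compound 1 (`COc1ccc(Nc2nccc(-c3c[nH]c4ccccc34)n2)c(OC(F)F)c1`) gives 4770 nM, while compound 2 (`COCCSc1nc(C)c(-c2ccnc(Nc3ccc(OC)cc3OC)n2)s1`) gives 810 nM. Among the compounds with values here, compound 2 therefore holds the lower of the only two numbers available, and the gap between them lies beyond the scatter. These two compounds differ in more than one place, so their values say nothing about any single structural change.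

Compound 3 (`COc1ccc(Nc2nccc(-c3sc(OC)nc3C)n2)c(OC)c1`) departs from compound 2 in one place. It has methoxy in place of (2-methoxyethyl)sulfanyl on an aromatic carbon of the five-membered aromatic ring with 1 nitrogen and 1 sulfur, next to the ring nitrogen and next to the ring sulfur: methoxy in place of (2-methoxyethyl)sulfanyl on an aromatic carbon. Within the data shown here, no measured pair shows a change of this kind, so the expectation is anchored only on compound 2 at 810 nM and carries wide uncertainty. The expected step is a 1.9-fold higher number from compound 2 to compound 3 (0.27 log units; within the scatter), a moderate move toward weaker inhibition of growth, although a step within the scatter cannot be excluded. For compound 3, the estimated value is 1500 nM, with an expected range of 500 nM to 5000 nM.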

Compound 3, concentration for 50% growth inhibition: 1400 nM
Compound 3: middle estimate off by 1.1-fold (0.03 log units), on the high side; measured number inside the range.
By their numbers in this assay, from the lowest: compounds 2 and 3 (each within the scatter of the next); then compound 1.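

Within the data shown here, this is the first comparison that isolates one structural change, and it concerns the aromatic carbon next to the ring nitrogen and next to the ring sulfur of the five-membered ring. In this assay, placing methoxy there in place of (2-methoxyethyl)sulfanyl gives a 1.7-fold higher number from compound 2 to compound 3 (0.24 log units; within the scatter), so the two compounds cannot be told apart and the full (2-methoxyethyl)sulfanyl chain is not needed to retain this level of growth inhibition. Nothing available explains why the exchange leaves the reading within the scatter, and no supporting data bear on this result.

The compounds shown leave open whether this position tolerates any substituent or only these two, since an amine, a carboxylic acid, a simple hydrogen or a longer chain on the same carbon could each give a different reading. They also do not show whether the same tolerance would hold if the neighbouring methyl group on the ring were replaced, for example by ethyl or by chlorine.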